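Moving the Pyridine Nitrogen in an Acrylamide Series

A few compounds are considered here, and "the series" means these few. Any claim that something is new, unique, unknown or untested is made for them only; others in the source may bear on it.

Three measured compounds in this set share the same core and differ in the linker to the tert-butylphenyl group and in the substitution on the amide. In a functional assay on CHO cells for inhibition of transient receptor potential cation channel subfamily V member 1 (Homo sapiens) (a lower number here means a stronger inhibitor, a higher number a weaker inhibitor), compound 1 `CN(C(=O)/C=C/c1ccc(C(C)(C)C)cc1)c1ccc2c(c1)OCCO2` gives only a limit, > 4000 nM, and that value is the limit of > 4000 nM in this assay, at which 1 of the 3 values shown sits. Compound 2 `CC(C)(C)c1ccc(CCC(=O)Nc2ccc3c(c2)OCCO3)cc1` gives 660 nM in this assay. Compound 3 `CC(C)(C)c1ccc(/C(=C/C(=O)Nc2ccc3c(c2)OCCO3)c2cccnc2)cc1` gives 510 nM in this assay, the lower of the two numbers that are not limits, yet its gap to compound 2 lies within the scatter, so the two cannot be ranked against each other. Among the measured compounds shown here, no pair of measured compounds differs in a single place, so no measured step is available to guide the next change.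

Compound 4 `CC(C)(C)c1ccc(/C(=C/C(=O)Nc2ccc3c(c2)OCCO3)c2ccncc2)cc1` differs from compound 3 by pyridin-4-yl in place of pyridin-3-yl on a double-bonded chain carbon bound to an aromatic carbon and a double-bonded chain carbon. The change moves the ring nitrogen within a ring of the same size and composition; nothing measured here shows how much that matters. The author expects a step from compound 3 to compound 4 of a 1.2-fold higher number from compound 3 to compound 4 (0.07 log units; within the scatter), not beyond the scatter in either direction. Compound 4 is therefore estimated at 600 nM, with a range from 200 nM to 2000 nM.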

Compound 4, half-maximal inhibitory concentration: 660 nM
Beside the measured number, compound 4's estimate is 1.1-fold (0.04 log units) below it; the range from low to high includes it.
By their numbers in this assay, from the lowest: compounds 3, 2 and 4 (each within the scatter of the next). At a limit, above all of these: compound 1.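

With this pair the set gains its first measured step at a single place. In this assay, pyridin-4-yl in place of pyridin-3-yl on a double-bonded chain carbon bound to an aromatic carbon and a double-bonded chain carbon gives a 1.3-fold higher number from compound 3 to compound 4 (0.11 log units; within the scatter), so compound 3 and compound 4 cannot be ranked against each other, and for these two pyridine rings the assay resolves no effect of where the ring nitrogen sits. Nothing measured alongside these compounds bears on why the step has this size.

The compounds shown leave open whether a ring nitrogen at this place matters at all, and whether a plain phenyl group or pyridin-2-yl on the same carbon would give a number in the same range as compound 3 and compound 4. They also leave open what a group of a different kind at this place, such as a carboxylic acid or a dimethylamino group, would do in this assay.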